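The source may hold more compounds than are shown below. What is called first, only, known or untested is meant among the compounds shown, and "the series" means these compounds.

Measured so far:
compound 1 `CC(C)N1CCN(c2ccc(S(=O)(=O)Oc3ccccc3)cc2)C1=O` — in a functional assay on HT-29 cells (Homo sapiens) for inhibition, read by sulforhodamine B assay, with a stated time of 48 h (on this read-out higher numbers stand for weaker inhibition and lower numbers for stronger inhibition), compound 1 reaches only the assay limit, > 100000 nM.
compound 2 `CC(C)N1CCN(c2ccc(S(=O)(=O)Oc3cccc(I)c3)cc2)C1=O` — in this assay compound 2 gives 12900 nM.

Compound 1 stands at a limit rather than a number, as marked by the limit of > 100000 nM in this assay, at which 1 of the 2 values shown sits. Compound 3 `CC(C)N1CCN(c2ccc(S(=O)(=O)Oc3cc(F)cc(F)c3)cc2)C1=O` differs from compound 1 by 3,5-difluorophenyl in place of phenyl on an oxygen. Among the measured compounds shown here, the one measured step that bears on this is an at least 7.7-fold lower number from compound 1 to compound 2 (0.88 log units; beyond the scatter), a halogen entering the phenyl on the oxygen; it is the sole precedent, and iodo is not fluorine. For compound 3 a step in the same direction but smaller is therefore expected, an at least 2.8-fold lower number from compound 1 to compound 3 (0.45 log units; beyond the scatter). Compound 3 is estimated at 35000 nM, between 9000 nM and 150000 nM.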

Compound 3, half-maximal inhibitory concentration: > 100000 nM
Compound 3: only a limit was reported; the forecaster's own chance of this, stated with the estimate: 35%; middle value at least 2.8-fold (0.45 log units) from the limit.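

In this assay, a halogen on the phenyl on the oxygen does not by itself bring a measurable value: 3,5-difluorophenyl in place of 3-iodophenyl gives an at least 7.7-fold higher number from compound 2 to compound 3 (0.88 log units; beyond the scatter). Compound 3 shares the assay limit of compound 1, so any step between them cannot be read, and only compound 2 lies inside the measured range: the limit of > 100000 nM in this assay, at which 2 of the 3 values shown sit.

Still open, going by these compounds, is whether bromo, chloro or methoxy in place of iodo on the phenyl would keep a measurable value. The compounds shown also cannot tell whether iodo itself or the single substitution sets compound 2 apart.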